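Replacing the Urea Link by an Amide on a Pyrazole Scaffold

The compounds below may be only part of what the source reports. "The series", "measured", "known", "first", "only" and "open" are said of these compounds alone.

Measured compounds:
compound 1 `COc1cc(Cl)cc(-c2nn(-c3cccc(NC(=O)Nc4ccc(Cl)c(C(F)(F)F)c4)c3)cc2-c2ccncc2)c1`, 96%
compound 2 `COc1cc(Cl)cc(-c2nn(-c3cccc(NC(=O)Nc4ccc(Cl)c(Cl)c4)c3)cc2-c2ccncc2)c1`, 98%
compound 3 `COc1cc(Cl)cc(-c2nn(-c3cccc(NC(=O)Nc4cccc(C(F)(F)F)c4)c3)cc2-c2ccncc2)c1`, 99%

In a functional assay on 786-0 cells (Homo sapiens) for inhibition, read by sulforhodamine B assay, with a stated time of 48 h, tested at 0.1 uM (on this read-out higher numbers stand for a weaker effect at the one concentration tested and lower numbers for a stronger effect), compound 1 gives 96%, compound 2 gives 98% and compound 3 gives 99%. Compound 3 holds the highest of the three numbers, yet all three sit within the scatter of one another: a number 2 percentage points higher from compound 1 to compound 2 (within the scatter), a number 3 percentage points higher from compound 1 to compound 3 (within the scatter) and a number 1 percentage points higher from compound 2 to compound 3 (within the scatter).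

Compound 4 `COc1cc(Cl)cc(-c2nn(-c3cccc(NC(=O)c4cccc(C(F)(F)F)c4)c3)cc2-c2ccncc2)c1` differs from compound 3 in one place: 3-(trifluoromethyl)phenyl in place of (3-(trifluoromethyl)phenyl)amino on a carbonyl carbon. Among the measured compounds shown here, none of the measured steps touches this link; they all concern the substituents on the outer aromatic ring and were each within the scatter. For the measured compounds named here, there is thus no measured precedent, and the estimate for compound 4 is a number 3 percentage points lower from compound 3 to compound 4 (within the scatter), a step not expected to exceed the scatter. Compound 4 is therefore expected to give 96% in this assay, within a range of 82% to 104%.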

Compound 4, a percentage reported as activity, at one concentration (the size of the read-out at that concentration, not a potency): 97%
The estimate for compound 4 lay 1 percentage points below the measured number; the measured number falls inside the stated range.
By their numbers in this assay, from the lowest: compounds 1, 4, 2 and 3 (each within the scatter of the next).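

In this assay, among the compounds shown here, the urea link itself changes for the first time, and the loss of the (3-(trifluoromethyl)phenyl)amino nitrogen with its hydrogen-bond donor leaves the read-out within the scatter (a number 2 percentage points lower from compound 3 to compound 4 (within the scatter)). The amide compound 4 also stays within the scatter of the other two ureas (a number 1 percentage points lower from compound 2 to compound 4 (within the scatter); a number 1 percentage points higher from compound 1 to compound 4 (within the scatter)). No available evidence bears on this result.

The compounds leave open whether a sulfonamide or a carbamate at this link would depart from these numbers. They also leave open whether an outer ring carrying an amine or a carboxylic acid would do so.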